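Cinnamate esters of a trimethoxyphenyl allyl alcohol: aryl variation

The compounds below may be only part of what the source reports. "The series", "measured", "known", "first", "only" and "open" are said of these compounds alone.

Measured so far:
compound 1, `COc1cc(OC)c(OC)cc1/C=C/COC(=O)/C=C/c1ccccc1C(F)(F)F`: 100%
compound 2, `COc1cc(OC)c(OC)cc1/C=C/COC(=O)/C=C/c1cccc(Br)c1`: 100%
compound 3, `COc1cc(OC)c(OC)cc1/C=C/COC(=O)/C=C/c1ccccc1Cl`: 100%

All three share one core and differ only in the aryl group at the far end of the ester. In a functional assay on the whole organism (strain Kunming) with Mus musculus as the target, with a stated time of 0.5 h, at a dose of 300 mg/kg by the intraperitoneal route (a higher number here means a weaker effect of the compound at the dose given, a lower number a stronger effect), compound 1 gives 100%. In this assay compound 2 gives 100% and compound 3 gives 100%. The three values stand level at the digits printed: no change at the digits printed from compound 1 to compound 2 (within the scatter), no change at the digits printed from compound 1 to compound 3 (within the scatter), no change at the digits printed from compound 2 to compound 3 (within the scatter). Among the measured compounds shown here, compound 3 therefore stands with compounds 1 and 2, no step to either reaching beyond the scatter.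

Compound 4, `COc1cc(OC)c(OC)cc1/C=C/COC(=O)/C=C/c1ccc(F)cc1`, is not yet measured in this assay. It differs from compound 3 as follows:
4-fluorophenyl in place of 2-chlorophenyl on a double-bonded chain carbon bound to a double-bonded chain carbon

For the measured compounds named here, the steps that bear on this change are those in which the aryl group on the double-bonded chain carbon was exchanged, from compound 1 to compound 2 and from compound 2 to compound 3, and both were flat. Exchanging one halogenated phenyl for another has so far left the read-out unmoved. On that basis, no step beyond the scatter is expected here either; the expected step is no change at the digits printed from compound 3 to compound 4 (within the scatter). For compound 4 in this assay the estimate is 100%, with a range from 85% to 100%.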

Compound 4, a percentage reported as activity, at one dose (the size of the read-out at that dose, not a potency): 100%
Compound 4: middle estimate and measured number agree at the digits printed; the measured number falls inside the stated range.
By their numbers in this assay, from the lowest: compounds 1, 2, 3 and 4 (each within the scatter of the next).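

The 4-fluorophenyl group brings both fluorine and a 4-substituted ring to this place, on a double-bonded chain carbon bound to a double-bonded chain carbon, and in this assay the read-out stays level against all three earlier aryl groups (no change at the digits printed from compound 3 to compound 4 (within the scatter)) (no change at the digits printed from compound 2 to compound 4 (within the scatter)) (no change at the digits printed from compound 1 to compound 4 (within the scatter)). Among the compounds shown here, the flat result, previously seen only with the 2-(trifluoromethyl)phenyl, 3-bromophenyl and 2-chlorophenyl groups, therefore also covers this new halogen and ring numbering, and neither feature separates the four compounds at this single dose. Nothing measured here offers an explanation for the level read-out.

On these data alone, all four aryl groups carry one halogen or trifluoromethyl substituent, so it remains open whether a phenyl group bearing an amine or a carboxylic acid, or an unsubstituted phenyl group, would depart from this level. Also open, as far as these compounds go, are whether these aryl groups would separate at a lower dose or a different read-out time, and whether changes to the shared core or to the ester link would move the read-out.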